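One More Chloro Group: Expecting No Change

A few compounds are considered here, and "the series" means these few. Any claim that something is new, unique, unknown or untested is made for them only; others in the source may bear on it.

The measured compounds so far:
Compound 1, `Cc1ccccc1NC(=O)N[C@@H](C)c1ccccc1`, which in an ADME assay on the whole organism with Oryza sativa as the target, tested at 1 uM (a lower number here means a stronger effect, a higher number a weaker effect of the compound at the concentration tested), gives 99% for compound 1.
Compound 2, `C[C@H](NC(=O)Nc1ccccc1Cl)c1ccccc1`, where compound 2 gives 104%.
Compound 3, `C[C@H](NC(=O)Nc1ccccc1Br)c1ccccc1`, where compound 3 gives 99%.

All three numbers lie close together. Compound 2 stands within the usual scatter of both its neighbours: the step of a number 5 percentage points higher from compound 1 to compound 2 (within the scatter) and the step of a number 5 percentage points lower from compound 2 to compound 3 (within the scatter) are each too small to count as a real difference, as is no change at the digits printed from compound 1 to compound 3 (within the scatter). Swapping methyl, chloro and bromo at the same aromatic carbon therefore leaves the read-out essentially where it was.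

Compound 4, `C[C@H](NC(=O)Nc1cccc(Cl)c1Cl)c1ccccc1`, is not yet measured. It differs from compound 2 by chloro in place of hydrogen on an aromatic carbon. For the measured compounds named here, none of the measured steps adds a second group to this ring, so none bears directly on the change; the only guidance is that every change tried so far on this ring, methyl to chloro, methyl to bromo and chloro to bromo, stayed within the scatter. On that basis the expected step of a number 4 percentage points lower from compound 2 to compound 4 (within the scatter) is none beyond the scatter. Compound 4 is therefore estimated at 100%, with a likely range from 88% to 112%.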

Compound 4, a percentage reported as activity, at one concentration (the size of the read-out at that concentration, not a potency): 100%
Estimate against measurement, compound 4: no gap at the digits printed; the range from low to high includes it.
By their numbers in this assay, from the lowest: compounds 1, 3, 4 and 2 (each within the scatter of the next).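

For the compounds shown here, every earlier step exchanged one group for another at a single ring carbon, whereas this is the first to add a group where only hydrogen stood, ortho to a chloro group and meta to a large group. The addition gives a number 4 percentage points lower from compound 2 to compound 4 (within the scatter) in this assay, so for this pair a second chloro group on the ring, at this new position, does not shift the read-out beyond what repeated measurements would scatter by. No separate measurement bears on this result, so the flat read-out stands as an observation without an explanation.

Chloro is the only group shown at this position, so it remains open whether an amine, a carboxylic acid or a longer chain there would leave the number equally unmoved. Because no step among these four compounds goes beyond the scatter, it also remains open which change to this ring, if any, would produce a real difference in this assay.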